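A Methylsulfonylphenyl Amide on a Chlorinated Core

The source may hold more compounds than are shown below. What is called first, only, known or untested is meant among the compounds shown, and "the series" means these compounds.

Compound 1 `Cc1nc(C(=O)Nc2ccc(Cl)c(-c3nnc4c(Cl)cccn34)c2)cs1` carries a 2-methyl-1,3-thiazol-4-yl on the carbonyl carbon. In a functional assay on HeLa cells (Homo sapiens) for antiproliferative activity, read by MTT assay, with a stated time of 72 h (a lower number here means a stronger inhibitor, a higher number a weaker inhibitor), compound 1 gives 79800 nM, the lowest of the two numbers shown, with compound 3 `O=C(Nc1ccc(Cl)c(-c2nnc3c(Cl)cccn23)c1)c1cccnc1Cl` nearest at 87500 nM. For compound 2 `CS(=O)(=O)c1ccc(C(=O)Nc2ccc(Cl)c(-c3nnc4c(Cl)cccn34)c2)cc1` only a limit is reported, > 100000 nM. Compound 4 `CS(=O)(=O)c1cccc(C(=O)Nc2ccc(Cl)c(-c3nnc4c(Cl)cccn34)c2)c1` has not yet been measured; it differs from compound 1 in one place: 3-(methylsulfonyl)phenyl in place of 2-methyl-1,3-thiazol-4-yl on a carbonyl carbon. The step with the closest bearing is an at least 1.2-fold higher number from compound 1 to compound 2 (0.09 log units; that floor lies within the scatter), and a 1.1-fold higher number from compound 1 to compound 3 (0.04 log units; within the scatter) also stays within the scatter. The expectation is therefore no step beyond the scatter, with a real chance that only a limit is returned, given (the limit of > 100000 nM in this assay, at which 1 of the 3 values shown sits). Compound 4 is estimated at 100000 nM, between 55000 nM and 200000 nM, a step of a 1.3-fold higher number from compound 1 to compound 4 (0.10 log units; within the scatter).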

Compound 4, half-maximal inhibitory concentration: 86400 nM
Compound 4: middle estimate off by 1.2-fold (0.06 log units), on the high side, and the stated range covers the measured number.
By their numbers in this assay, from the lowest: compounds 1, 4 and 3 (each within the scatter of the next). At a limit, above all of these: compound 2.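

In this assay, the 3-(methylsulfonyl)phenyl group gives a 1.1-fold higher number from compound 1 to compound 4 (0.03 log units; within the scatter) and a 1.0-fold lower number from compound 3 to compound 4 (0.01 log units; within the scatter), so this position now holds three different aromatic groups with no step beyond the scatter. Moving the methylsulfonyl group gives an at least 1.1-fold lower number from compound 2 to compound 4 (0.06 log units; that floor lies within the scatter), so the two phenyl isomers cannot be told apart. The value of compound 2 is a limit and not a number: the limit of > 100000 nM in this assay, at which 1 of the 4 values shown sits.

On these data alone, whether any group on this carbonyl carbon can move the number beyond the scatter stays open. An amine or a carboxylic acid on the phenyl ring, or a longer alkyl chain in its place, would test this.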